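Benzyl swap on the shared core from a weak start

The source may hold more compounds than are shown below. What is called first, only, known or untested is meant among the compounds shown, and "the series" means these compounds.

Compound 1 `Cc1ccc(CNc2ncnc3c2ncn3[C@@H]2O[C@H](CO)[C@@H](O)[C@H]2O)cc1` gives in a functional assay on K562 cells (Homo sapiens) for antiproliferative activity, with a stated time of 72 h (a higher number here means a weaker inhibitor, a lower number a stronger inhibitor), only a limit, > 166000 nM. In this assay compound 2 `OC[C@H]1O[C@@H](n2cnc3c(NCc4cccc(O)c4O)ncnc32)[C@H](O)[C@@H]1O` gives 25800 nM, and the step of an at least 6.4-fold lower number from compound 1 to compound 2 (0.80 log units; beyond the scatter) shows one swap at this position moving the number. Compound 3 `OC[C@H]1O[C@@H](n2cnc3c(NCc4cccc(C(F)(F)F)c4)ncnc32)[C@H](O)[C@@H]1O` differs from compound 1 by 3-(trifluoromethyl)phenyl in place of 4-methylphenyl on a saturated chain carbon bound to a nitrogen on an aromatic ring. Going by the values given here, no measured step carries this change; the only step on hand concerns a different group. Because compound 1 sits at the limit of > 166000 nM in this assay, at which 1 of the 2 values shown sits, only a lower bound is known for it. The expected step is an at least 1.6-fold lower number from compound 1 to compound 3 (0.22 log units; that floor lies within the scatter). For compound 3 the estimate is 100000 nM, ranging from 30000 nM to 250000 nM.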

Compound 3, half-maximal inhibitory concentration: > 166000 nM
Compound 3: no number, only a limit; the forecaster's own chance of this, stated with the estimate: 45%; middle value at least 1.6-fold (0.22 log units) away from the limit.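

In this assay compound 3 gives > 166000 nM, which is a limit and not a number. Replacing 2,3-dihydroxyphenyl with 3-(trifluoromethyl)phenyl gives an at least 6.4-fold higher number from compound 2 to compound 3 (0.80 log units; beyond the scatter), so of the three groups shown on this saturated chain carbon, only 2,3-dihydroxyphenyl gives a reading short of the limit: the limit of > 166000 nM in this assay, at which 2 of the 3 values shown sit. The step between compound 1 and compound 3 cannot be read, as both values are limits.

As far as these compounds go, whether both hydroxyl groups of 2,3-dihydroxyphenyl are needed remains open. Also open, from the compounds shown here alone, is whether a phenyl bearing a single hydroxyl, an amine or a carboxylic acid would give a number here.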